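The source may hold more compounds than are shown below. What is called first, only, known or untested is meant among the compounds shown, and "the series" means these compounds.

Measured compounds:
compound 1 `CNC(=O)c1cc(Oc2ccc(Nc3nccc(N4CCCC4)n3)cc2)ccn1` gives 46.6%;
compound 2 `CN(c1ccc(Oc2ncnc3sccc23)cc1)c1nccc(N2CCCC2)n1` gives 31%;
compound 3 `CNC(=O)c1cc(Oc2ccc(Nc3nccc(N4CCCCC4)n3)cc2)ccn1` gives 52.3%.

These three values come from a functional assay on MDA-MB-231 cells (Homo sapiens) for inhibition, read by MTT assay, with a stated time of 72 h, tested at 20 uM; on this read-out lower numbers stand for less inhibition and higher numbers for more inhibition at the one concentration tested (going by the name of the read-out). Compound 1 and compound 3 share one core and differ in a single place, described as piperidin-1-yl in place of pyrrolidin-1-yl on an aromatic carbon. Their measured step is a number 5.7 percentage points higher from compound 1 to compound 3 (within the scatter), so the two values cannot be told apart by order. Compound 2 carries a different core; the difference between the two cores is not broken down here. Its number in this assay is the lowest of the three, and its gaps to compound 1 and to compound 3 lie beyond the scatter.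

Compound 4 `CN(c1ccc(Oc2ncnc3sccc23)cc1)c1nccc(N2CCCCC2)n1` has not yet been measured. It stands to compound 2 as compound 3 stands to compound 1, the change being (piperidin-1-yl in place of pyrrolidin-1-yl on an aromatic carbon), the same change at the same place. Because the step of a number 5.7 percentage points higher from compound 1 to compound 3 (within the scatter) stayed within the scatter, a step of similar size, a number 5 percentage points higher from compound 2 to compound 4 (within the scatter), is expected from compound 2 to compound 4. On that basis compound 4 is estimated at 36% in this assay, with the expected range from 22% to 50%.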

Compound 4, a percentage reported as inhibition, at one concentration (the size of the read-out at that concentration, not a potency): 29.3%
Compound 4: the middle estimate sits 6.7 percentage points above what was measured; measured number inside the range.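

In this assay, putting piperidin-1-yl in place of pyrrolidin-1-yl on the second core gives a number 1.7 percentage points lower from compound 2 to compound 4 (within the scatter), so the two values cannot be told apart by order. Set beside the same change on the first core, the step shows no difference between the two cores: the same change on two cores in this assay, a number 5.7 percentage points higher (within the scatter) from compound 1 to compound 3 and a number 1.7 percentage points lower (within the scatter) from compound 2 to compound 4, 7.4 percentage points apart, within the scatter of two such steps This shows that, in these two pairs at the one concentration tested, the change produced no step beyond the scatter on either core; it does not show that the cores respond alike to other changes, and it gives no measure of potency.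

The compounds shown leave open what other groups on this aromatic carbon would do on either core, such as morpholin-4-yl, an open-chain dimethylamino group or a piperazine bearing a free amine. They also leave open whether a ring-to-ring swap of this kind would stay within the scatter at other concentrations of the same assay.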